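The source may report more compounds than this note shows. Statements on the series, on what has been measured and on what is new or still open speak of the compounds shown alone.

Measured so far:
compound 1 `CCCCCCCC/C=C/C1CC(=O)c2ccccc2N1C` — 24 ug/mL
compound 2 `CCCCCCCCCC/C=C/C1CC(=O)c2ccccc2N1C` — 24 ug/mL

In a functional assay on RAW264.7 cells (Mus musculus) for inhibition, read by fluorescence and resazurin assay, with a stated time of 48 h (on this read-out higher numbers stand for weaker inhibition and lower numbers for stronger inhibition), compound 1 gives 24 ug/mL and compound 2 gives 24 ug/mL, so compound 2 stands level with compound 1. Compound 3 `CCCCCCCCCCC/C=C/C1CC(=O)c2ccccc2N1C` differs from compound 2 by methyl in place of hydrogen on a saturated chain carbon, ten or more bonds along the chain from a double-bonded chain carbon. Among the measured compounds shown here, one measured step bears on this change: no change at the digits printed from compound 1 to compound 2 (within the scatter), a lengthening of the same chain that left the read-out unchanged. A further single-carbon lengthening is therefore expected to give no step beyond the scatter, no change at the digits printed from compound 2 to compound 3 (within the scatter). For compound 3 the expected value is 24 ug/mL, with a range from 12 ug/mL to 48 ug/mL.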

Compound 3, half-maximal inhibitory concentration: 24 ug/mL
Beside the measured number, compound 3's estimate shows no gap at the digits printed, and the stated range covers the measured number.
By their numbers in this assay, from the lowest: compounds 1, 2 and 3 (each within the scatter of the next).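

In this assay, methyl in place of hydrogen at this far point on the saturated chain gives no change at the digits printed from compound 2 to compound 3 (within the scatter) and, taken together with the earlier lengthening, propyl in place of hydrogen gives no change at the digits printed from compound 1 to compound 3 (within the scatter) across the series. All three chain lengths shown therefore read alike, so this stretch of chain has now tolerated two successive extensions without a step beyond the scatter. Nothing measured here explains this result. On these data alone, whether a much longer chain would keep the same reading stays open. So does the effect of an amine or a carboxylic acid placed on this chain.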